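A few compounds are considered here, and "the series" means these few. Any claim that something is new, unique, unknown or untested is made for them only; others in the source may bear on it.

Measured compounds in this set:

compound 1 `Cc1cc(-c2ccc(C=O)cc2)cn2c(CSCCc3ccccc3)cnc12` — 9.4 ug/mL
compound 2 `Cc1cc(-c2ccc3[nH]ccc3c2)cn2c(CSCCc3ccccc3)cnc12` — 26 ug/mL
compound 3 `Cc1cc(N2CCCC2)cn2c(CSCCc3ccccc3)cnc12` — 12 ug/mL

All three share one core and differ only in the group on the aromatic carbon. In an ADME assay on HEL cells (Homo sapiens) for cytotoxicity, with a stated time of 3 days (on this read-out higher numbers stand for lower toxicity in this test and lower numbers for higher toxicity in this test), compound 2 gives the highest number of the three: the nearest is compound 3, and the step of a 2.2-fold lower number from compound 2 to compound 3 (0.34 log units; beyond the scatter) is beyond the scatter, as is a 2.8-fold higher number from compound 1 to compound 2 (0.44 log units; beyond the scatter) in the other direction. Compounds 1 and 3 sit within the scatter of each other, a 1.3-fold higher number from compound 1 to compound 3 (0.11 log units; within the scatter).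

Compound 4 `Cc1cc(C#N)cn2c(CSCCc3ccccc3)cnc12` has not yet been measured. Relative to compound 2 the change is cyano in place of 1H-indol-5-yl on an aromatic carbon. Among the measured compounds shown here, two measured steps bear on it, since both replace 1H-indol-5-yl with another group at the same aromatic carbon: a 2.2-fold lower number from compound 2 to compound 3 (0.34 log units; beyond the scatter) and, read in reverse, a 2.8-fold higher number from compound 1 to compound 2 (0.44 log units; beyond the scatter). In each case leaving 1H-indol-5-yl gives a modestly lower number in this assay, whether the entering group is pyrrolidin-1-yl or 4-formylphenyl. Cyano is a far smaller group than either, so the size of the step is uncertain, but the direction is expected to match: a modest drop, a 2.4-fold lower number from compound 2 to compound 4 (0.37 log units; beyond the scatter), to about the level of compounds 1 and 3.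

Compound 4 is therefore estimated at 11 ug/mL in this assay, with a range of 5 ug/mL to 25 ug/mL.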

Compound 4, half-maximal cytotoxic concentration: 14 ug/mL
For compound 4 the middle estimate is 1.3-fold (0.10 log units) below the measured one; low and high end bracket the measured number.
By their numbers in this assay, from the lowest: compounds 1, 3, 4 and 2 (each within the scatter of the next, the first and the last beyond it).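

In this assay, cyano on this aromatic carbon, a group of 2 heavy atoms with no ring, gives a 1.9-fold lower number from compound 2 to compound 4 (0.27 log units; within the scatter), so leaving 1H-indol-5-yl does not always produce a step beyond the scatter, as the two earlier steps from that group might have suggested. Cyano also reads level with the two other groups, at a 1.2-fold higher number from compound 3 to compound 4 (0.07 log units; within the scatter) and a 1.5-fold higher number from compound 1 to compound 4 (0.17 log units; within the scatter), so this small ring-free group cannot be told apart here from pyrrolidin-1-yl or 4-formylphenyl. Compound 2 now stands apart from compounds 1 and 3 only, not from compound 4, and no trend with the size of the group can be read across these four compounds.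

No measurement at hand explains the readings at this position. Still open is whether a charged group at this carbon, such as a carboxylic acid or a primary amine, would move the number beyond the scatter of compound 4, and whether replacing the methyl group on the shared core would alter the small differences seen among these four compounds.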